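A Small Branch on Compound 3

The source may hold more compounds than are shown below. What is called first, only, known or untested is meant among the compounds shown, and "the series" means these compounds.

Within the data shown here, in a functional assay on A549 cells (Homo sapiens) for antiproliferative activity, read by CCK-8 assay, with a stated time of 72 h (on this read-out higher numbers stand for weaker inhibition and lower numbers for stronger inhibition), only two of the three compounds tested so far have a number. Compound 1 `O=C(NO)c1ccc(COc2ccccc2)cc1` gives 28000 nM. For compound 2 `Nc1ccccc1NC(=O)c1ccc(CN2CCc3cc(Br)ccc32)cc1` the entry reads "not determined" (no result reported). Compound 3 `CCc1ccc(OCc2ccc(C(=O)Nc3ccccc3N)cc2)cc1` gives 6420 nM, the lower of the two numbers and so the stronger inhibition, with a gap to compound 1 that lies beyond the scatter.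

The next compound to be tested is compound 4 `CC(C)c1ccc(OCc2ccc(C(=O)Nc3ccccc3N)cc2)cc1`. It differs from compound 3 by methyl in place of hydrogen on a saturated chain carbon bound to an aromatic carbon and a saturated chain carbon, which turns ethyl into isopropyl. Among the measured compounds shown here, no measured pair shows what such a change does, so the expectation rests on compound 3 at 6420 nM and on the smallness of the change. The expected 1.1-fold lower number from compound 3 to compound 4 (0.03 log units; within the scatter) in this assay is small, with no shift in either direction beyond the scatter. For compound 4 the estimated value is 6000 nM, with an expected range from 2700 nM to 13000 nM.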

Compound 4, half-maximal inhibitory concentration: 7460 nM
Compound 4: middle estimate off by 1.2-fold (0.09 log units), on the low side, within the range that was stated.
By their numbers in this assay, from the lowest: compounds 3 and 4 (each within the scatter of the next); then compound 1.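

With this result, the series in this assay holds its first measured pair that differs in one place (a 1.2-fold higher number from compound 3 to compound 4 (0.07 log units; within the scatter)). At this saturated chain carbon bound to an aromatic carbon and a saturated chain carbon, methyl in place of hydrogen turns 4-ethylphenyl into 4-isopropylphenyl and leaves two numbers that cannot be told apart, so this one added carbon has no effect that the assay can resolve. No measured finding is available to explain this outcome.

What the compounds shown leave open is whether the same place would stay as undemanding with a larger group, such as tert-butyl or a longer chain. As far as these compounds go, whether an amine or a carboxylic acid there would move the number beyond the scatter also remains open.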